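Swapping nitrophenyl for dichlorophenyl on the amide nitrogen

This account rests on a few compounds, and the source may have more. Where it says the series, first, only, none or still open, it means among the compounds named here.

Within the data shown here, compound 2 `O=C(CSc1nc(Nc2ccccc2)c2ccccc2n1)Nc1ccc([N+](=O)[O-])cc1` gives 13000 nM in a functional assay on NCI-H1975 cells (Homo sapiens) for inhibition, read by MTT assay, with a stated time of 72 h (a higher number here means a weaker inhibitor, a lower number a stronger inhibitor), the higher of the two numbers measured so far. Its nearest neighbour, compound 1 `O=C(CSc1nc(Nc2ccccc2)c2ccccc2n1)Nc1ccc(Cl)cc1`, gives 8040 nM in this assay. Compound 3 `O=C(CSc1nc(Nc2ccccc2)c2ccccc2n1)Nc1ccc(Cl)c(Cl)c1` differs from compound 2 by 3,4-dichlorophenyl in place of 4-nitrophenyl on an amide-type nitrogen. Among the measured compounds shown here, the only step measured so far bears on it in reverse: a 1.6-fold higher number from compound 1 to compound 2 (0.21 log units; within the scatter), so returning from nitro to chloro, with a second chlorine added, is not expected to move the number beyond the scatter. Compound 3 is therefore expected to give 7000 nM, between 2500 nM and 20000 nM, which means a step of a 1.9-fold lower number from compound 2 to compound 3 (0.27 log units; within the scatter).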

Compound 3, half-maximal inhibitory concentration: 10400 nM
For compound 3 the middle estimate is 1.5-fold (0.17 log units) below the measured one, and the stated range covers the measured number.
By their numbers in this assay, from the lowest: compounds 1, 3 and 2 (each within the scatter of the next).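

Chloro in place of hydrogen on an aromatic carbon gives a 1.3-fold higher number from compound 1 to compound 3 (0.11 log units; within the scatter) in this assay and the full swap of the ring on the amide-type nitrogen gives a 1.3-fold lower number from compound 2 to compound 3 (0.10 log units; within the scatter); both steps lie within the scatter. On this phenyl ring, then, one chlorine, two chlorines and a nitro group give numbers that cannot be told apart in these three compounds. Nothing at hand offers an explanation for this. Open, going by these compounds, is whether an amine or a carboxylic acid on this ring would move the number beyond the scatter, and whether a longer chain on the amide nitrogen in place of the ring would do so.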